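This account rests on a few compounds, and the source may have more. Where it says the series, first, only, none or still open, it means among the compounds named here.

In an assay for inhibition of NAD-dependent protein deacylase sirtuin-6 (Homo sapiens), read by HPLC, with stated times of 15 min and 1 h, tested at 333 uM (a lower number here means less inhibition, a higher number more inhibition at the concentration tested (going by the name of the read-out)), compound 1 `CCCCNC(=O)CCCSC[C@H](NC(=O)OCc1ccccc1)C(=O)Nc1ccccc1` gives 26%. For the measured compounds named here, the only other compound measured, compound 2 `O=C(O)CCCNC(=O)CCCSC[C@H](NC(=O)OCc1ccccc1)C(=O)Nc1ccccc1`, gives 35% in this assay, and compound 1 stands level with it because a number 9 percentage points higher from compound 1 to compound 2 (within the scatter) lies within the scatter. Compound 3 `O=C(O)CNC(=O)CCCSC[C@H](NC(=O)OCc1ccccc1)C(=O)Nc1ccccc1` differs from compound 1 by carboxy in place of propyl on a saturated chain carbon bound to an amide-type nitrogen. Going by the values given here, that measured step is the one comparison that also brings a carboxy group into the chain, and it did not move the read-out beyond the scatter, so for compound 3 the expected change is a number 4 percentage points higher from compound 1 to compound 3 (within the scatter), essentially none. Compound 3 is therefore estimated at 30%, within 15% to 45%.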

Compound 3, a percentage reported as inhibition, at one concentration (the size of the read-out at that concentration, not a potency): 53%
Compound 3: the middle estimate sits 23 percentage points below what was measured; the measured number lies above the stated range.
By their numbers in this assay, from the lowest: compounds 1 and 2 (each within the scatter of the next); then compound 3.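

Swapping propyl for carboxy on the saturated chain carbon bound to an amide-type nitrogen gives a number 27 percentage points higher from compound 1 to compound 3 (beyond the scatter) in this assay, so a carboxy group can shift this read-out beyond the scatter when it sits on this shorter chain. Carboxy in place of 2-carboxyethyl gives a number 18 percentage points higher from compound 2 to compound 3 (beyond the scatter), which shows that the length of the chain carrying the carboxy group matters at this position. Nothing available here explains this difference.

From the compounds shown here alone, it remains open whether an amine or a methyl ester in place of the carboxy group would read as high on the same short chain. A 2-carboxyethyl chain, one carbon shorter than that of compound 2, would show whether the read-out falls gradually with chain length.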